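The compounds below may be only part of what the source reports. "The series", "measured", "known", "first", "only" and "open" are said of these compounds alone.

Compound 1 `CN(C)CC[C@H](CSc1ccccc1)Nc1ccc(S(=O)(=O)Nc2ccc(N3CCN(c4cccc(-c5cncn5-c5ccc(Cl)cc5)c4)CC3)cc2)cc1[N+](=O)[O-]` gives the lowest number of the two measured compounds in an assay on isolated protein for binding affinity to Apoptosis regulator Bcl-2 (Homo sapiens), read by fluorescence polarization, with a stated time of 2 h (a higher number here means a weaker inhibitor, a lower number a stronger inhibitor), at 46 nM. Compound 2 `CN(C)CC[C@H](CSc1ccccc1)Nc1ccc(S(=O)(=O)Nc2ccc(N3CCN(c4cccc(-c5ccnn5-c5ccc(Cl)cc5)c4)CC3)cc2)cc1[N+](=O)[O-]` gives 110 nM in this assay, and the step of a 2.4-fold higher number from compound 1 to compound 2 (0.38 log units; beyond the scatter) arises from exchanging one ring pair for another. Compound 3 `CN(C)CC[C@H](CSc1ccccc1)Nc1ccc(S(=O)(=O)Nc2ccc(N3CCN(c4cccc(-c5c(C(=O)NS(C)(=O)=O)ncn5-c5ccc(Cl)cc5)c4)CC3)cc2)cc1[N+](=O)[O-]` differs from compound 1 by (methylsulfonyl)carbamoyl in place of hydrogen on an aromatic carbon. Going by the values given here, no measured step covers an addition of this kind; the single known step concerns a ring exchange and offers no direct guide, so the uncertainty is wide. For compound 3 the expected step is a 1.5-fold higher number from compound 1 to compound 3 (0.18 log units; within the scatter). Compound 3 is estimated at 70 nM, within a range from 20 nM to 300 nM.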

Compound 3, half-maximal inhibitory concentration: 3.8 nM
The estimate for compound 3 lay 18-fold (1.27 log units) above the measured number, and the stated range ends above it.
By their numbers in this assay, from the lowest: compound 3; then compound 1; then compound 2.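

Placing (methylsulfonyl)carbamoyl on this aromatic carbon of the five-membered ring gives a 12-fold lower number from compound 1 to compound 3 (1.08 log units; beyond the scatter) in this assay, a large gain in binding. The earlier compounds shown here differed only in their ring pair, so they said nothing about adding a group at this carbon; this result shows that a group of this size is accepted here and can strengthen binding. Nothing available explains the gain.

On these data alone, whether the entire group is needed remains open. A carboxylic acid or a primary amide on the same carbon would test how much of the gain depends on the methylsulfonyl part.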